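A few compounds are considered here, and "the series" means these few. Any claim that something is new, unique, unknown or untested is made for them only; others in the source may bear on it.

Measured compounds:

Compound 1: `CCCCOC(=O)/C=C/c1ccc2c(c1)C(=O)C(=O)N2Cc1ccc(Br)cc1` — 150 nM
Compound 2: `CCOC(=O)/C=C/c1ccc2c(c1)C(=O)C(=O)N2Cc1ccc(Br)cc1` — 30 nM

Of the compounds shown here, two have been tested in a functional assay on K562 cells (Homo sapiens) for cytotoxicity, read by MTT assay, with a stated time of 48 h; on this read-out lower numbers stand for stronger inhibition and higher numbers for weaker inhibition. Compound 1 gives 150 nM there, while compound 2 gives 30 nM, the lowest of the two numbers. Within the data shown here, the only measured step is a 5.0-fold lower number from compound 1 to compound 2 (0.70 log units; beyond the scatter), and it concerns the length of the chain on the ester oxygen: the butyl group of compound 1 is shortened to the ethyl group of compound 2, and the number falls.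

The next compound, compound 3, is `O=C1C(=O)N(Cc2ccc(Br)cc2)c2ccc(/C=C/C(=O)N3CCCC3)cc21`. The change from compound 2 is pyrrolidin-1-yl in place of ethoxy on a carbonyl carbon. Here the ethoxy group leaves and a pyrrolidin-1-yl group enters on the carbonyl carbon whose other neighbour is a double-bonded chain carbon, so the ester becomes an amide-like group carrying a five-membered ring.

Among the measured compounds shown here, no measured step describes an exchange of this kind. The step from compound 1 to compound 2 alters only chain length on the same carbonyl and offers no direct guide. The expectation for compound 3 is therefore a number near that of compound 2, with a wide margin; the estimated step is a 2.0-fold higher number from compound 2 to compound 3 (0.30 log units; within the scatter). Compound 3 is estimated at 60 nM, within a range from 10 nM to 350 nM.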

Compound 3, half-maximal inhibitory concentration: 1710 nM
For compound 3 the middle estimate is 29-fold (1.45 log units) below the measured one; measured number outside the range, above it.
By their numbers in this assay, from the lowest: compound 2; then compound 1; then compound 3.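

In this assay, this position on the carbonyl carbon proves far more sensitive to swapping the group attached through oxygen for a ring attached through nitrogen than the two esters alone could show: putting pyrrolidin-1-yl in place of ethoxy gives a 57-fold higher number from compound 2 to compound 3 (1.76 log units; beyond the scatter), and putting it in place of butoxy gives an 11-fold higher number from compound 1 to compound 3 (1.06 log units; beyond the scatter). Both steps are large and beyond the scatter, whereas the change in ester chain length was modest, so among these three compounds, both esters give lower numbers than the compound carrying pyrrolidin-1-yl, whichever of the two ester chains is compared. Nothing measured alongside these compounds accounts for the rise.

With a single nitrogen-linked group in the set, the compounds shown cannot separate the effect of the ring from the effect of replacing the ester oxygen with nitrogen. An open-chain diethylamino group on the same carbonyl carbon would address that question, while a carboxylic acid there or a methoxy group in place of ethoxy would show how far the ester side of the series extends.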